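The source may report more compounds than this note shows. Statements on the series, on what has been measured and on what is new or still open speak of the compounds shown alone.

Working notes on the series, read in a physicochemical assay for solubility (on this read-out lower numbers stand for lower solubility and higher numbers for higher solubility), on the shared core. Compound 1 `O=C(c1nc2c(C(F)(F)F)cc(-c3ccoc3)cn2c1Cl)N1CCC(c2ccccc2F)C1` gives < 15000 nM, which is a limit. Compound 2 `O=C(c1nc2c(C(F)(F)F)cc(-c3ccoc3)cn2c1Cl)N1CCC(c2cccs2)C1` gives < 15000 nM, also a limit. Compound 3 `O=C(c1nc2c(C(F)(F)F)cc(-c3ccoc3)cn2c1Cl)N1CCC(N2CCCC2)CC1` gives > 500000 nM, again a limit, so no number is known for it.

Compound 4 `O=C(c1nc2c(C(F)(F)F)cc(-c3ccoc3)cn2c1Cl)N1CCC(N2CCCC2=O)CC1` carries 2-oxopyrrolidin-1-yl in place of pyrrolidin-1-yl on a saturated ring carbon.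

Going by the values given here, the only measured step is a step that the two limits leave unreadable from compound 1 to compound 2. Among the compounds with values here, it concerns other groups and has no readable size, so no measured step bears directly on this change.

A downward step is expected in this assay, of a real size beyond the scatter. This expectation rests only on the high-side limit of compound 3 at > 500000 nM, and the basis is weak. Compounds 1 and 2 mark the low end of the series, and a reading at that end is possible.

The expected step is an at least 12-fold lower number from compound 3 to compound 4 (1.09 log units; beyond the scatter). For compound 4 the estimated value is 40000 nM, with an expected range from 12000 nM to 200000 nM.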

Compound 4, solubility: > 500000 nM
Compound 4: no number, only a limit; the forecaster's own chance of this, stated with the estimate: 35%; at least 12-fold (1.09 log units) between middle value and limit.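

In this assay, compound 3 and compound 4 both stand only as limits, so no step can be read for 2-oxopyrrolidin-1-yl in place of pyrrolidin-1-yl. The compounds shown leave open how far each lies beyond its limit, and which of the two gives the higher number.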